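Amide substituent changes on the shared core

This account rests on a few compounds, and the source may have more. Where it says the series, first, only, none or still open, it means among the compounds named here.

Going by the values given here, compound 1 `Nc1sc(-c2ccc(Cl)cc2)c(-c2ccc(Cl)cc2)c1C(=O)N1CCCCC1=O` gives 4940 nM in a functional assay on PC-3 cells (Homo sapiens) for inhibition, read by sulforhodamine B assay, with a stated time of 72 h (a lower number here means a stronger inhibitor, a higher number a weaker inhibitor), the lowest of the two numbers measured so far. Among the compounds with values here, compound 2 `CN1CCN(C(=O)c2c(N)sc(-c3ccc(Cl)cc3)c2-c2ccc(Cl)cc2)CC1` gives 13100 nM in this assay; the only measured step is a 2.7-fold higher number from compound 1 to compound 2 (0.42 log units; beyond the scatter). Compound 3 `Nc1sc(-c2ccc(Cl)cc2)c(-c2ccc(Cl)cc2)c1C(=O)N1CCNCC1` carries piperazin-1-yl in place of 2-oxopiperidin-1-yl on a carbonyl carbon. The measured step bears on this change, as compound 2 also differs from compound 1 only at the same carbonyl carbon, and it was modest, beyond the scatter, toward a higher number. For compound 3 a step of similar size in the same direction is expected, a 2.0-fold higher number from compound 1 to compound 3 (0.31 log units; beyond the scatter). Compound 3 is estimated at 10000 nM, with a range of 4000 nM to 25000 nM.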

Compound 3, half-maximal inhibitory concentration: 2710 nM
The estimate for compound 3 lay 3.7-fold (0.57 log units) above the measured number, and the stated range ends above it.
By their numbers in this assay, from the lowest: compounds 3 and 1 (each within the scatter of the next); then compound 2.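

In this assay, piperazin-1-yl in place of 2-oxopiperidin-1-yl on the carbonyl carbon gives a 1.8-fold lower number from compound 1 to compound 3 (0.26 log units; within the scatter) and so does not separate these two amides, unlike the 4-methylpiperazin-1-yl step. Hydrogen in place of methyl on the ring amine nitrogen gives a 4.8-fold lower number from compound 2 to compound 3 (0.68 log units; beyond the scatter) and so, among these three compounds, the higher number goes with that methyl and not with the piperazine ring itself. No measurement shown gives a reason for either step.

Open: whether an acetyl group or a longer alkyl chain on that ring nitrogen tracks with compound 2 or compound 3, and how an open-chain amine behaves on the same carbonyl carbon.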